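The source may hold more compounds than are shown below. What is called first, only, known or untested is meant among the compounds shown, and "the series" means these compounds.

Measured so far:
compound 1 `O=c1[nH]c(=O)n([C@H]2C[C@H](O)[C@@H](CO)O2)cc1/C=C/I`: 63900 nM
compound 2 `N#Cc1cn([C@H]2C[C@H](O)[C@@H](CO)O2)c(=O)[nH]c1=O`: > 200000 nM (a limit)
compound 3 `CCC#Cc1cn([C@H]2C[C@H](O)[C@@H](CO)O2)c(=O)[nH]c1=O`: > 200000 nM (a limit)

All three values come from an ADME assay on L1210/0 cells (Mus musculus) for cytotoxicity, with a stated time of 48 h (a lower number here means a stronger inhibitor, a higher number a weaker inhibitor), and only compound 1 gives an actual number. For compound 3 the entry > 200000 nM is a limit of the assay and not a number. Compound 2 also stops at a limit, with > 200000 nM. The series therefore has (the limit of > 200000 nM in this assay, at which 2 of the 3 values shown sit).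

Compound 4 `C#COc1cn([C@H]2C[C@H](O)[C@@H](CO)O2)c(=O)[nH]c1=O` has not yet been measured. It carries ethynyloxy in place of but-1-yn-1-yl on an aromatic carbon, (ethynyloxy in place of but-1-yn-1-yl on an aromatic carbon).

Among the compounds with values here, three measured steps bear on this change. Two of them, an at least 3.1-fold higher number from compound 1 to compound 2 (0.49 log units; beyond the scatter) and an at least 3.1-fold higher number from compound 1 to compound 3 (0.49 log units; beyond the scatter), are at least modest and lie beyond the scatter, but both start from the 2-iodoethenyl group, which plays no part in the present change. The third, a step that the two limits leave unreadable from compound 2 to compound 3, swaps a group at the same place, yet its size cannot be read. Within the data shown here, no measured step therefore gives the size of this change directly.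

Compound 3 holds the limit > 200000 nM, so compound 4 is expected to stay close to it, with no step beyond the scatter. The expected step is an at least 1.3-fold lower number from compound 3 to compound 4 (0.12 log units; that floor lies within the scatter). For compound 4 the estimated value is 150000 nM, within an expected range of 50000 nM to 400000 nM.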

Compound 4, half-maximal inhibitory concentration: > 200000 nM
Compound 4: only a limit was reported (the forecaster's own chance of this, stated with the estimate: 55%); middle value at least 1.3-fold (0.12 log units) from the limit.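

In this assay, exchanging but-1-yn-1-yl for ethynyloxy brings in an oxygen and a hydrogen-bond acceptor on this aromatic carbon, yet the entry for compound 4 is again only a limit of the assay and not a number. Within the data shown here, the one readable step, an at least 3.1-fold higher number from compound 1 to compound 4 (0.49 log units; beyond the scatter), matches in kind those seen for cyano and but-1-yn-1-yl, so ethynyloxy becomes the third group at this position that stands apart from 2-iodoethenyl by a step beyond the scatter. Among these compounds, the steps among compound 2, compound 3 and compound 4 cannot be read, and 2-iodoethenyl remains the only group here with an actual number, the rest of the series resting on a single limit: the limit of > 200000 nM in this assay, at which 3 of the 4 values shown sit.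

Going by these compounds, how cyano, but-1-yn-1-yl and ethynyloxy compare with one another, or whether they differ at all in this assay, stays open. The compounds shown also leave open whether a 2-bromoethenyl group, a plain ethenyl group or a longer chain at this position would give a measurable value, and so whether the iodine or the ethenyl part of compound 1 matters for its value.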